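The compounds below may be only part of what the source reports. "The series", "measured", "known", "first", "only" and "open" are said of these compounds alone.

Compound 1 `CCc1c(C)[nH]c2cc(OC)c(F)cc2c1=O`: 19.1 10^-6 cm/s
Compound 2 `CCc1c(C)[nH]c2cc(OC)c(Cl)cc2c1=O`: 57.3 10^-6 cm/s

In an ADME assay for permeability, using PAMPA, at pH 7.4 (a higher number here means that the compound crosses the layer faster, a lower number that the compound crosses the layer more slowly), compound 2 holds the higher of the two numbers, with a 3.0-fold higher number from compound 1 to compound 2 (0.48 log units; beyond the scatter). Compound 3 `C=C(CCCCC)c1c(C)[nH]c2cc(OC)c(Cl)cc2c1=O` departs from compound 2 by a group of 7 heavy atoms (7 carbon; no ring) in place of a group of 2 heavy atoms (2 carbon; no ring), on an aromatic carbon. Among the measured compounds shown here, the one measured step, chloro in place of fluoro on an aromatic carbon, lies elsewhere on the shared core and bears on this change only loosely. For the measured compounds named here, no step at the ethyl position has been measured, so the direction is uncertain. A step of similar modest size toward a lower number is expected, a 2.3-fold lower number from compound 2 to compound 3 (0.36 log units; beyond the scatter). For compound 3 the estimated value is 25 10^-6 cm/s, with an expected range of 6 10^-6 cm/s to 90 10^-6 cm/s.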

Compound 3, apparent permeability: 755 10^-6 cm/s
For compound 3 the middle estimate is 30-fold (1.48 log units) below the measured one; the measured number lies above the stated range.
By their numbers in this assay, from the lowest: compound 1; then compound 2; then compound 3.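

In this assay the aromatic carbon carrying ethyl, ortho to a methyl group, proves highly responsive: the change to the unsaturated group gives a 13-fold higher number from compound 2 to compound 3 (1.12 log units; beyond the scatter) and no loss. The step comes with no change in hydrogen-bond donors, acceptors or net charge, and the incoming group has a double bond outside aromatic rings. Nothing available accounts for the size of this step.

Going by these compounds, whether chain length or the double bond carries the rise remains open; a saturated chain of the same length would separate them. On these data alone, how an amine or carboxylic acid at this position would behave is also open.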